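A few compounds are considered here, and "the series" means these few. Any claim that something is new, unique, unknown or untested is made for them only; others in the source may bear on it.

In a functional assay on HeLa cells (Homo sapiens) for inhibition, read by MTT assay (on this read-out higher numbers stand for weaker inhibition and lower numbers for stronger inhibition), compound 1 `CCCCCCCCn1cc(/C=C/C(=O)c2ccc(NC(=O)CN3CCN(c4ccccc4OC)CC3)cc2)nn1` gives 26800 nM. Compound 2 `CCCCCCCCCCn1cc(/C=C/C(=O)c2ccc(NC(=O)CN3CCN(c4ccccc4OC)CC3)cc2)nn1` gives 50800 nM, and compound 3 `COc1ccccc1N1CCN(CC(=O)Nc2ccc(C(=O)/C=C/c3cn(Cc4ccc(Br)cc4)nn3)cc2)CC1` gives 26400 nM. These three differ from one another only in the group on a saturated chain carbon bound to an aromatic nitrogen, and every step among them stayed small: a 1.9-fold higher number from compound 1 to compound 2 (0.28 log units; within the scatter), a 1.0-fold lower number from compound 1 to compound 3 (0.01 log units; within the scatter) and a 1.9-fold lower number from compound 2 to compound 3 (0.28 log units; within the scatter). Going by the values given here, compound 3 carries the lowest number of the three, but all three sit within the scatter of each other, so no compound can be called stronger or weaker than another.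

Compound 4 `O=C(CN1CCN(c2ccc([N+](=O)[O-])cc2)CC1)Nc1ccc(C(=O)/C=C/c2cn(Cc3ccc(Br)cc3)nn2)cc1` has not been measured. It alters a different part of the molecule: 4-nitrophenyl in place of 2-methoxyphenyl on an amine nitrogen in a ring. Among the compounds with values here, no measured step touches this part; each one concerned the group on the saturated chain carbon, and all of them fell within the scatter. There is thus nothing measured to lean on, and no direction beyond the scatter can be expected. Compound 4 is estimated to give 26000 nM, with a range from 8000 nM to 85000 nM. The expected step is a 1.0-fold lower number from compound 3 to compound 4 (0.01 log units; within the scatter), which is to say essentially none.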

Compound 4, half-maximal inhibitory concentration: 26600 nM
Compound 4: middle estimate off by 1.0-fold (0.01 log units), on the low side, within the range that was stated.
By their numbers in this assay, from the lowest: compounds 3, 4, 1 and 2 (each within the scatter of the next).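

Going by these compounds alone, until now, every step concerned the group on the saturated chain carbon; compound 4 is the first to test the group on the amine nitrogen in the six-membered ring. In this assay, putting 4-nitrophenyl in place of 2-methoxyphenyl gives a 1.0-fold higher number from compound 3 to compound 4 (0.00 log units; within the scatter), so the two compounds cannot be told apart. This position therefore holds two differently substituted phenyl groups with no measurable difference, although the entering group carries an extra hydrogen-bond acceptor. Nothing available here bears on what lies behind this result.

As far as these compounds go, whether the same holds for a phenyl ring carrying an amine or a carboxylic acid, or for a plain methyl on this nitrogen, remains open. From the compounds shown here alone, it is also open whether this exchange would read the same on the chain of compound 1.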